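The source may report more compounds than this note shows. Statements on the series, on what has been measured and on what is new or still open speak of the compounds shown alone.

Series notes. Compound 1 `COc1cc(Cc2cnc(/N=C3\C(=O)N(CN4CCN(c5ccc(F)cc5)CC4)c4ccc(Cl)cc43)nc2N)cc(OC)c1OC` gives 65.6 ug/mL in an ADME assay on MT4 cells (Homo sapiens) for cytotoxicity, read by MTT assay, with a stated time of 5 days; a higher number here means that more compound is tolerated, a lower number that less compound is tolerated; compound 2 `COc1cc(Cc2cnc(/N=C3\C(=O)N(CN4CCN(C)CC4)c4ccc(Cl)cc43)nc2N)cc(OC)c1OC` gives 80.7 ug/mL and compound 3 `COc1cc(Cc2cnc(/N=C3\C(=O)N(CN4CCN(c5cccc(Cl)c5)CC4)c4ccc(Cl)cc43)nc2N)cc(OC)c1OC` gives 39.2 ug/mL in this assay. Compound 3 stands at the low end of the three numbers, though the gap shown by a 1.7-fold lower number from compound 1 to compound 3 (0.22 log units; within the scatter) is within the scatter, while a 2.1-fold lower number from compound 2 to compound 3 (0.31 log units; beyond the scatter) is beyond it. Compound 4 `COc1cccc(N2CCN(CN3C(=O)/C(=N\c4ncc(Cc5cc(OC)c(OC)c(OC)c5)c(N)n4)c4cc(Cl)ccc43)CC2)c1` differs from compound 3 by methoxy in place of chloro on an aromatic carbon. Among the compounds with values here, no measured step alters the phenyl group on the amine nitrogen in this way; the nearest, a 1.7-fold lower number from compound 1 to compound 3 (0.22 log units; within the scatter), exchanges one phenyl group for another without effect beyond the scatter, whereas a 1.2-fold higher number from compound 1 to compound 2 (0.09 log units; within the scatter) and the modest 2.1-fold lower number from compound 2 to compound 3 (0.31 log units; beyond the scatter) concern methyl. The step expected for compound 4 is a 1.2-fold higher number from compound 3 to compound 4 (0.09 log units; within the scatter), no larger than the scatter. The estimate for compound 4 in this assay is 48 ug/mL, with range 25 ug/mL to 95 ug/mL.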

Compound 4, half-maximal cytotoxic concentration: 32.6 ug/mL
The estimate for compound 4 lay 1.5-fold (0.17 log units) above the measured number; the range from low to high includes it.
By their numbers in this assay, from the lowest: compounds 4, 3, 1 and 2 (each within the scatter of the next, the first and the last beyond it).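

In this assay, the exchange on the aromatic carbon itself, 3-chlorophenyl to 3-methoxyphenyl, gives a 1.2-fold lower number from compound 3 to compound 4 (0.08 log units; within the scatter), so this position tolerates this change without a shift beyond the scatter. Replacing the methyl of compound 2 with 3-methoxyphenyl gives a 2.5-fold lower number from compound 2 to compound 4 (0.39 log units; beyond the scatter), a modest step beyond the scatter, while replacing the 4-fluorophenyl of compound 1 gives a 2.0-fold lower number from compound 1 to compound 4 (0.30 log units; within the scatter), which stays within it. Nothing available explains these steps. Still open, on these data alone, is whether an amine or a carboxylic acid on this aromatic carbon would also stay within the scatter of compound 3.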